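A few compounds are considered here, and "the series" means these few. Any claim that something is new, unique, unknown or untested is made for them only; others in the source may bear on it.

In a functional assay on HL-60 cells (Homo sapiens) for cytotoxicity, read by MTT assay, with a stated time of 72 h (on this read-out lower numbers stand for stronger inhibition and higher numbers for weaker inhibition), compound 1 `COc1ccc(S(=O)(=O)c2nc3ccccc3nc2N2CCCC2)cc1` gives 16000 nM and compound 2 `O=S(=O)(c1ccc(F)cc1)c1nc2ccccc2nc1N1CCCC1` gives 12800 nM, so the two stand level within the scatter. Compound 3 `O=S(=O)(c1ccc(F)cc1)c1nc2ccccc2nc1N1CCCC(O)C1` carries 3-hydroxypiperidin-1-yl in place of pyrrolidin-1-yl on an aromatic carbon, (3-hydroxypiperidin-1-yl in place of pyrrolidin-1-yl on an aromatic carbon). For the measured compounds named here, the only measured step, a 1.3-fold lower number from compound 1 to compound 2 (0.10 log units; within the scatter), is fluoro in place of methoxy at another place and lies within the scatter. Going by the values given here, no measured step covers this change, so no shift beyond the scatter is expected in this assay, and the range stays wide. Compound 3 is expected at 13000 nM, with an estimated range of 5000 nM to 32000 nM. The estimated step is a 1.0-fold higher number from compound 2 to compound 3 (0.01 log units; within the scatter).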

Compound 3, half-maximal inhibitory concentration: 2620 nM
Compound 3: middle estimate off by 5.0-fold (0.70 log units), on the high side; measured number outside the range, below it.
By their numbers in this assay, from the lowest: compound 3; then compounds 2 and 1 (each within the scatter of the next).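

In this assay, for the compounds shown here, the position on the aromatic carbon next to the ring nitrogen responds to the amine ring: 3-hydroxypiperidin-1-yl in place of pyrrolidin-1-yl gives a 4.9-fold lower number from compound 2 to compound 3 (0.69 log units; beyond the scatter) and is the first step to exceed the scatter. This single change enlarges the ring and adds a hydroxy group together. Nothing available explains the step.

Ring size and the hydroxy group remain inseparable on these compounds. Open too, going by these compounds, is how piperidin-1-yl without the hydroxy group, or morpholin-4-yl, would read at this position.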